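The source may hold more compounds than are shown below. What is called first, only, known or untested is meant among the compounds shown, and "the series" means these compounds.

The measured compounds, in a functional assay on KM12 cells (Homo sapiens) for inhibition, read by sulforhodamine B assay, with a stated time of 48 h; on this read-out higher numbers stand for weaker inhibition of growth and lower numbers for stronger inhibition of growth:

Compound 1 `CN1CCN(CCCOc2cccc3nc(Nc4ccc(Cl)c(F)c4)ccc23)CC1` gives 1770 nM.
Compound 2 `CC(C)c1ccc(Nc2ccc3c(OCCCN4CCN(C)CC4)cccc3n2)cc1` gives 11300 nM.
Compound 3 `CN1CCN(CCCOc2cccc3nc(Nc4ccc(F)c(F)c4)ccc23)CC1` gives 2350 nM.

Compound 3 stands second highest of the three numbers: the step of a 1.3-fold higher number from compound 1 to compound 3 (0.12 log units; within the scatter) lies within the scatter, while the step of a 4.8-fold lower number from compound 2 to compound 3 (0.68 log units; beyond the scatter) lies beyond it. Compound 4 `CN1CCN(CCCOc2cccc3nc(Nc4cc(Cl)cc(Cl)c4)ccc23)CC1` has not yet been measured. It differs from compound 3 in one place: 3,5-dichlorophenyl in place of 3,4-difluorophenyl on a nitrogen on an aromatic ring.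

Two kinds of measured step bear on this change. The exchange of one halogen for another, a 1.3-fold higher number from compound 1 to compound 3 (0.12 log units; within the scatter), stayed within the scatter, so a swap between fluoro and chloro carries little weight here. The steps of a 6.4-fold higher number from compound 1 to compound 2 (0.81 log units; beyond the scatter) and a 4.8-fold lower number from compound 2 to compound 3 (0.68 log units; beyond the scatter) show that replacing the whole aryl group can shift this assay modestly, but both involve an isopropyl group that compound 4 does not carry. Going by the values given here, no measured pair moves a halogen to another place on that ring. The expected step is therefore a 1.3-fold lower number from compound 3 to compound 4 (0.12 log units; within the scatter), within the scatter. Compound 4 is estimated at 1800 nM, with a range from 700 nM to 5000 nM.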

Compound 4, concentration for 50% growth inhibition: 1720 nM
For compound 4 the middle estimate is 1.0-fold (0.02 log units) above the measured one; the range from low to high includes it.
By their numbers in this assay, from the lowest: compounds 4, 1 and 3 (each within the scatter of the next); then compound 2.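

In this assay, the exchange of 3,4-difluorophenyl for 3,5-dichlorophenyl alters both the halogen and its placing on the ring, yet the result is a 1.4-fold lower number from compound 3 to compound 4 (0.14 log units; within the scatter). Compound 4 also cannot be told apart from the 4-chloro-3-fluorophenyl compound, with a 1.0-fold lower number from compound 1 to compound 4 (0.01 log units; within the scatter), while a 6.6-fold lower number from compound 2 to compound 4 (0.82 log units; beyond the scatter) keeps the 4-isopropylphenyl compound apart, so among these compounds the three dihalogenated aryl groups fall together and compound 2 alone stands off from them. Nothing measured here explains either the closeness of the three or their distance from compound 2.

The compounds shown leave open whether a methoxy group or a nitrile on the aryl ring would stay with the dihalogenated compounds or fall nearer compound 2. They also leave open what a longer chain between the shared core and its terminal amine would do to growth inhibition.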